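This account rests on a few compounds, and the source may have more. Where it says the series, first, only, none or still open, it means among the compounds named here.

Measured in a functional assay on NCI/ADR cells (Homo sapiens) for cytotoxicity, read by sulforhodamine B assay; a higher number here means a weaker inhibitor of growth, a lower number a stronger inhibitor of growth:
- Compound 1 `CC1=CC[C@@H]([C@@](C)(O)CCCC(C)(C)NC(=S)N/N=C\c2ccc([N+](=O)[O-])cc2)CC1`: > 100000 nM (a limit)
- Compound 2 `CC1=CC[C@@H]([C@@](C)(O)CCCC(C)(C)NC(=S)N/N=C\c2cccc(Cl)c2)CC1`: 31900 nM

The value of compound 1, > 100000 nM, is a limit and not a number. Among the measured compounds shown here, compound 2 therefore holds the only true number. Compound 3 `CC1=CC[C@@H]([C@@](C)(O)CCCC(C)(C)NC(=S)N/N=C\c2ccc(Cl)cc2)CC1` differs from compound 2 as follows: 4-chlorophenyl in place of 3-chlorophenyl on a carbon with a double bond to nitrogen, with 4-chlorophenyl in place of 3-chlorophenyl on a carbon with a double bond to nitrogen. For the measured compounds named here, the one measured step at this place, an at least 3.1-fold lower number from compound 1 to compound 2 (0.49 log units; beyond the scatter), exchanged a different group and is only a loose guide. The step expected in this assay is a 1.1-fold higher number from compound 2 to compound 3 (0.04 log units; within the scatter), with no change beyond the scatter anticipated. For compound 3 the estimated value is 35000 nM, within an expected range of 13000 nM to 95000 nM.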

Compound 3, concentration for total growth inhibition: 36400 nM
Compound 3: the middle estimate sits 1.0-fold (0.02 log units) below what was measured; low and high end bracket the measured number.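

In this assay, 4-chlorophenyl in place of 3-chlorophenyl gives a 1.1-fold higher number from compound 2 to compound 3 (0.06 log units; within the scatter), so these two placements of chloro are not told apart here. Chloro in place of nitro on an aromatic carbon gives an at least 2.7-fold lower number from compound 1 to compound 3 (0.43 log units; beyond the scatter), which shows that the separation from the nitro compound holds for both chlorophenyl compounds. Compound 1 stands at a limit and not a number, so this step has no exact size: the limit of > 100000 nM in this assay, at which 1 of the 3 values shown sits. From the compounds shown here alone, how an amine or a methoxy group on this phenyl ring would compare remains open, as does the effect of any change to the shared core.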